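Aryl substituent change from compound 3 to compound 4

The source may report more compounds than this note shows. Statements on the series, on what has been measured and on what is new or still open speak of the compounds shown alone.

compound 1 `CC(C)(C)n1cc2c(n1)C(=O)CC1(CCN(C(=O)c3cc(-c4ccccc4)nc4ccccc34)CC1)O2` gives 1940 nM
compound 2 `CC(C)(C)n1cc2c(n1)C(=O)CC1(CCN(C(=O)c3cc(-c4ccc(Cl)cc4)nc4ccccc34)CC1)O2` gives 2330 nM
compound 3 `COc1ccc(-c2cc(C(=O)N3CCC4(CC3)CC(=O)c3nn(C(C)(C)C)cc3O4)c3ccccc3n2)cc1` gives 3740 nM

In a functional assay on A549 cells (Homo sapiens) for inhibition, read by MTT assay, with a stated time of 72 h (a lower number here means a stronger inhibitor, a higher number a weaker inhibitor), compound 3 stands level with the other two measured compounds, with a 1.9-fold higher number from compound 1 to compound 3 (0.29 log units; within the scatter) and a 1.6-fold higher number from compound 2 to compound 3 (0.21 log units; within the scatter) both within the scatter. Compound 4 `CN(C)c1ccc(-c2cc(C(=O)N3CCC4(CC3)CC(=O)c3nn(C(C)(C)C)cc3O4)c3ccccc3n2)cc1` has dimethylamino in place of methoxy on an aromatic carbon. Those two steps bear on this change, as does the step between the remaining pair (a 1.2-fold higher number from compound 1 to compound 2 (0.08 log units; within the scatter)), and none leaves the scatter. Nothing beyond the scatter is therefore expected in this assay, and the data suggest no direction. The expected change is small (a 1.2-fold lower number from compound 3 to compound 4 (0.10 log units; within the scatter)). Compound 4 is estimated at 3000 nM (range 1500 nM to 6000 nM).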

Compound 4, half-maximal inhibitory concentration: 1150 nM
Compound 4: the middle estimate sits 2.6-fold (0.42 log units) above what was measured, outside the stated range (below it).
By their numbers in this assay, from the lowest: compounds 4, 1, 2 and 3 (each within the scatter of the next, the first and the last beyond it).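

In this assay, going by these compounds alone, the change from 4-methoxyphenyl to 4-(dimethylamino)phenyl is the first step at this position to leave the scatter (a 3.3-fold lower number from compound 3 to compound 4 (0.51 log units; beyond the scatter)). Dimethylamino in place of chloro also leaves it (a 2.0-fold lower number from compound 2 to compound 4 (0.31 log units; beyond the scatter)), while dimethylamino in place of hydrogen stays within it (a 1.7-fold lower number from compound 1 to compound 4 (0.23 log units; within the scatter)), so the compounds shown set dimethylamino apart from methoxy and chloro but not from the unsubstituted phenyl. No measured data on these compounds account for the step.

As far as these compounds go, whether the step is specific to dimethylamino or also holds for a primary amine or diethylamino at this position remains open. From the compounds shown here alone, the effect of a carboxylic acid there is equally open.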